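Replacing the trimethoxyphenyl group of compound 1

The source may report more compounds than this note shows. Statements on the series, on what has been measured and on what is new or still open speak of the compounds shown alone.

Measured in a functional assay on KYSE-450 cells (Homo sapiens) for inhibition, read by CCK-8 assay, with a stated time of 48 h; a higher number here means a weaker inhibitor, a lower number a stronger inhibitor
compound 1 `COc1ccc(CN(C(=O)CSC(=S)N2CCN(C(=O)OC(C)(C)C)CC2)c2cc(OC)c(OC)c(OC)c2)cc1` gives 250 nM
compound 2 `COc1ccc(CN(C(=O)CSC(=S)N2CCN(Cc3ccc(C(C)(C)C)cc3)CC2)c2cc(OC)c(OC)c(OC)c2)cc1` gives 2140 nM

Compound 1 holds the lowest of these two numbers, which makes it the stronger inhibitor so far. Compound 3 `COc1ccc(CN(C(=O)CSC(=S)N2CCN(C(=O)OC(C)(C)C)CC2)c2ccc(Cl)cc2)cc1` differs from it in one group, with 4-chlorophenyl in place of 3,4,5-trimethoxyphenyl on an amide-type nitrogen and the rest unchanged. Within the data shown here, the only measured step of an 8.6-fold higher number from compound 1 to compound 2 (0.93 log units; beyond the scatter) lies at another place, an amine nitrogen in a ring, so it offers only a rough scale. Among the measured compounds shown here, a step of similar size toward a higher number in this assay is expected, though no measurement yet tests this position. Compound 3 is estimated at 800 nM with an expected range from 150 nM to 4000 nM in this assay. That estimate means a 3.2-fold higher number from compound 1 to compound 3 (0.51 log units; beyond the scatter) as the expected step.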

Compound 3, half-maximal inhibitory concentration: > 20000 nM
Compound 3: a limit, no number; the forecaster's own chance of this, stated with the estimate: 3%; middle value at least 25-fold (1.39 log units) from the limit.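

This amide-type nitrogen proves a sensitive place in the molecule. In this assay 4-chlorophenyl in place of 3,4,5-trimethoxyphenyl gives a large loss (an at least 80-fold higher number from compound 1 to compound 3 (1.90 log units; beyond the scatter)), well beyond the earlier change on the amine nitrogen in a ring (an 8.6-fold higher number from compound 1 to compound 2 (0.93 log units; beyond the scatter)). For compound 3 the reading is a limit and not a number: the limit of > 20000 nM in this assay, at which 1 of the 3 values shown sits.

This one change removes the methoxy groups and adds chlorine together, so the compounds shown do not tell which part matters. Going by these compounds, how an unsubstituted phenyl or a 3,5-dimethoxyphenyl on this nitrogen would read stays open.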